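Methyl on the Ring Nitrogen: From Compound 2 to Compound 3

The compounds below may be only part of what the source reports. "The series", "measured", "known", "first", "only" and "open" are said of these compounds alone.

Compound 1 `O=C(O)c1cc2ccc(OCCc3ccccc3)cc2oc1=O` and compound 2 `O=C(O)c1cc2ccc(OCc3ccccc3)cc2[nH]c1=O` were both tested in an assay on SiHa cells for inhibition of Monocarboxylate transporter 4 (Homo sapiens), read by scintillation counting, with a stated time of 24 h; a higher number here means a weaker inhibitor, a lower number a stronger inhibitor. In this assay compound 1 gives 2400 nM. For compound 2 this assay reports only a limit, > 30000 nM. Compound 2 therefore stands at the weak end of the two numbers shown, without an exact value, and sits at the limit of > 30000 nM in this assay, at which 1 of the 2 values shown sits. Compound 3 `Cn1c(=O)c(C(=O)O)cc2ccc(OCc3ccccc3)cc21` has not been measured yet. It differs from compound 2 by methyl in place of hydrogen on an aromatic nitrogen, in words methyl in place of hydrogen on an aromatic nitrogen. Among the measured compounds shown here, no measured pair of compounds shows this change, so nothing here tells how large its effect is. Compound 3 is expected to remain a weak inhibitor in this assay. The step from compound 2 to compound 3 is estimated as an at least 1.2-fold lower number from compound 2 to compound 3 (0.07 log units; that floor lies within the scatter). Compound 3 is expected to give about 25000 nM, between 6000 nM and 100000 nM.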

Compound 3, half-maximal inhibitory concentration: > 30000 nM
Compound 3: only a limit was reported; the forecaster's own chance of this, stated with the estimate: 55%; at least 1.2-fold (0.07 log units) between middle value and limit.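

In this assay compound 3 gives only a limit, > 30000 nM, and compound 2 also has only a limit, so no step can be read between these two compounds. As far as these compounds go, how much methyl in place of hydrogen on an aromatic nitrogen changes inhibition, if at all, remains open.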